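A few compounds are considered here, and "the series" means these few. Any claim that something is new, unique, unknown or untested is made for them only; others in the source may bear on it.

Compound 1 `CS/C(=N\C(=O)c1sccc1Cl)NC(=O)c1sccc1Cl` was examined in a functional assay on HepG2 cells (Homo sapiens) for cytotoxicity, read by MTT assay, with a stated time of 72 h; a higher number here means that more compound is tolerated, a lower number that less compound is tolerated. In this assay compound 1 gives > 100000 nM, which is a limit of the assay rather than a number. Compound 2 `CS/C(=N\C(=O)c1ccno1)NC(=O)c1ccno1` has a different core, and the difference between the two cores is not broken down here. In this assay compound 2 gives > 100000 nM, again a limit. Compound 3 `C[Se]/C(=N\C(=O)c1ccno1)NC(=O)c1ccno1` carries a group of 2 heavy atoms (1 carbon, 1 selenium; no ring) in place of a group of 2 heavy atoms (1 carbon, 1 sulfur; no ring), on a carbon with a double bond to nitrogen. In this assay compound 3 gives > 100000 nM, also a limit. The step that the two limits leave unreadable from compound 2 to compound 3 therefore cannot be read in size. Compound 4 `C[Se]/C(=N\C(=O)c1sccc1Cl)NC(=O)c1sccc1Cl` carries the same change, (a group of 2 heavy atoms (1 carbon, 1 selenium; no ring) in place of a group of 2 heavy atoms (1 carbon, 1 sulfur; no ring), on a carbon with a double bond to nitrogen), on the core of compound 1. Because the limit of > 100000 nM in this assay, at which 3 of the 3 values shown sit, holds for every measured compound, the step from compound 1 to compound 4 is expected to be a step that the limit leaves unreadable from compound 1 to compound 4, beside the earlier one that stays unreadable. Compound 4 is thus estimated at 150000 nM, with an expected range from 60000 nM to 400000 nM.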

Compound 4, concentration lethal to 50% of the cells: 8670 nM
The estimate for compound 4 lay 17-fold (1.24 log units) above the measured number, outside the stated range (below it).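

In this assay, the group with selenium in place of methylsulfanyl, on the core of compound 1, goes with an at least 11-fold lower number from compound 1 to compound 4 (1.06 log units; beyond the scatter) on that core. On the core of compound 2 the size of the same change cannot be read, so it cannot be said whether the step carries over from one core to the other, because compound 2 and compound 3 both stand at a limit: the limit of > 100000 nM in this assay, at which 3 of the 4 values shown sit. For the compounds shown here, the one readable step thus shows that the change can lower the number on one core, not that it does so in general.

From the compounds shown here alone, whether an amine or a longer chain in place of methylsulfanyl would give a similar step stays open. Going by these compounds, how the change behaves on further cores stays open too.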